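Halogen Swap on the Anisole Ring: Fluoro to Chloro

This account rests on a few compounds, and the source may have more. Where it says the series, first, only, none or still open, it means among the compounds named here.

Compound 1 `COc1ccc(N(C)c2cc(C)nc(C)n2)cc1`: 322 nM
Compound 2 `COc1ccc(N(C)c2cc(C)nc(C)n2)cc1F`: 471 nM

In a functional assay on HeLa cells (Homo sapiens) for antiproliferative activity, read by MTT assay, with a stated time of 48 h (on this read-out higher numbers stand for weaker inhibition and lower numbers for stronger inhibition), compound 2 and compound 1 sit within the scatter of each other, the step of a 1.5-fold higher number from compound 1 to compound 2 (0.17 log units; within the scatter) being too small to read as a real change. Compound 3 `COc1ccc(N(C)c2cc(C)nc(C)n2)cc1Cl` differs from compound 2 by chloro in place of fluoro on an aromatic carbon. Among the measured compounds shown here, the only step that bears on this change is the one from hydrogen to fluoro at the same carbon, and it stayed within the scatter, so no step beyond the scatter is expected in this assay. For compound 3 the expected step is a 1.0-fold lower number from compound 2 to compound 3 (0.02 log units; within the scatter). Compound 3 is therefore estimated at 450 nM, within a range of 200 nM to 1000 nM.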

Compound 3, half-maximal inhibitory concentration: 316 nM
For compound 3 the middle estimate is 1.4-fold (0.15 log units) above the measured one, within the range that was stated.
By their numbers in this assay, from the lowest: compounds 3, 1 and 2 (each within the scatter of the next).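

In this assay, chloro on this aromatic carbon, ortho to a methoxy group, stays within the scatter of both neighbours (a 1.5-fold lower number from compound 2 to compound 3 (0.17 log units; within the scatter)) and (a 1.0-fold lower number from compound 1 to compound 3 (0.01 log units; within the scatter)). Hydrogen, fluoro and chloro at this position therefore cannot be told apart on this read-out, which the step from hydrogen to fluoro alone could not show for chloro. No evidence is available to explain why these numbers stay so close. As far as these compounds go, it remains open whether an amine, a nitrile or a carboxylic acid on this carbon would give a step beyond the scatter. From the compounds shown here alone, whether chloro would behave the same way on the other carbons of this ring also remains open.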